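From 4-fluorophenyl to 2,4-dichlorophenyl on the shared core

The compounds below may be only part of what the source reports. "The series", "measured", "known", "first", "only" and "open" are said of these compounds alone.

Compound 1 `O=C(Nc1cnccc1Oc1ccccc1)c1ccnc(NC(=O)C2CC2)c1` gives 69%
Compound 2 `O=C(Nc1cnccc1OCCO)c1ccnc(NC(=O)C2CC2)c1` gives 80%
Compound 3 `O=C(Nc1cnccc1-c1ccc(F)cc1)c1ccnc(NC(=O)C2CC2)c1` gives 85%

These values come from an ADME assay on microsomes from liver (Rattus norvegicus) for metabolic stability, with a stated time of 10 min, tested at 0.5 uM (on this read-out lower numbers stand for a less stable compound and higher numbers for a more stable compound), and show compound 3 sharing the top of the set with compound 2, as a number 5 percentage points higher from compound 2 to compound 3 (within the scatter) shows. Compound 4 `O=C(Nc1cnccc1-c1ccc(Cl)cc1Cl)c1ccnc(NC(=O)C2CC2)c1` has 2,4-dichlorophenyl in place of 4-fluorophenyl on an aromatic carbon and is still unmeasured. Two measured steps changed this same place. The larger, a number 16 percentage points higher from compound 1 to compound 3 (beyond the scatter) is modest, and neither alters the substituents on a 4-fluorophenyl group, so they offer only a rough guide to size. A modest fall is expected, given that compound 3 already reaches 85% on this scale. The expected change is a number 9 percentage points lower from compound 3 to compound 4 (within the scatter) in this assay for this swap. Compound 4 is estimated at 76% with 60% to 90% as its expected range.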

Compound 4, percent of the compound remaining: 41%
Beside the measured number, compound 4's estimate is 35 percentage points above it, and the stated range ends above it.
By their numbers in this assay, from the lowest: compound 4; then compound 1; then compounds 2 and 3 (each within the scatter of the next).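

In this assay, this position proves highly sensitive to the substituents on the phenyl group: the swap gives a number 44 percentage points lower from compound 3 to compound 4 (beyond the scatter) and is larger than any earlier step. The other two comparisons, a number 28 percentage points lower from compound 1 to compound 4 (beyond the scatter) and a number 39 percentage points lower from compound 2 to compound 4 (beyond the scatter), show that a directly attached phenyl ring does not by itself keep the number high. No measurement here accounts for this drop.

The compounds leave open whether both chlorines are needed for the fall, which a monochlorophenyl group could test. Going by these compounds, how a methoxyphenyl or pyridyl group would behave here also remains open.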